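The compounds below may be only part of what the source reports. "The series", "measured", "known", "first", "only" and "open" are said of these compounds alone.

Values in an ADME assay on HepG2 cells (Homo sapiens) for cytotoxicity, read by MTT assay, with a stated time of 24 h; on this read-out higher numbers stand for lower toxicity in this test and lower numbers for higher toxicity in this test:
- compound 1 `CC1Cn2c(nc([N+](=O)[O-])c2Br)O1`: 20100 nM
- compound 2 `CC1Cn2c(nc([N+](=O)[O-])c2-c2cccc(C#N)c2)O1`: > 500000 nM (a limit of the assay, not a number)
- compound 3 `CC1Cn2c(nc([N+](=O)[O-])c2C#Cc2ccc(CO)cc2)O1`: 9000 nM

Within the data shown here, of the two actual numbers, the one for compound 1 is the higher, and the number for compound 3 lies lower by a gap beyond the scatter. Compound 4 `CC1Cn2c(nc([N+](=O)[O-])c2C#CC2CC2)O1` is not yet measured. It differs from compound 1 as follows: 2-cyclopropylethynyl in place of bromo on an aromatic carbon. In words, this is 2-cyclopropylethynyl in place of bromo on an aromatic carbon. Compound 3 also has a triple bond outside aromatic rings at this place and gives 9000 nM, so no step beyond the scatter is expected in this assay. The estimated step is a 1.2-fold higher number from compound 1 to compound 4 (0.09 log units; within the scatter). For compound 4 the estimate is 25000 nM, with an expected range of 6000 nM to 150000 nM.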

Compound 4, half-maximal cytotoxic concentration: 14800 nM
Compound 4: the middle estimate sits 1.7-fold (0.23 log units) above what was measured; the range from low to high includes it.
By their numbers in this assay, from the lowest: compounds 3, 4 and 1 (each within the scatter of the next, the first and the last beyond it). At a limit, above all of these: compound 2.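

In this assay, among these compounds, 2-cyclopropylethynyl in place of bromo on this aromatic carbon gives a 1.4-fold lower number from compound 1 to compound 4 (0.13 log units; within the scatter), the first one-place comparison at this position. Losing bromo here therefore brings no step beyond the scatter, and compound 4 at 14800 nM and compound 3 at 9000 nM, both with a triple bond at this place, lie within the scatter of each other. No measured property on hand bears on this step.

From the compounds shown here alone, compound 2 gives > 500000 nM, which is a limit and not a number, so its distance from the others stays open. Also open, going by these compounds, is whether an amine or a carboxylic acid on the triple bond would stay in this range.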